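Sulfonamide in place of dienamide on a weak cytotoxic series

The source may report more compounds than this note shows. Statements on the series, on what has been measured and on what is new or still open speak of the compounds shown alone.

Compound 1, `CCCCCCCCCCCCCCCCCCNC(=O)[C@@H](NC(=O)c1cc2ccccc2o1)[C@@H](C)O`: > 200000 nM
Compound 2, `CCCCCCCCCCCCCCCCCCNC(=O)[C@@H](NC(=O)c1nccc2ccccc12)[C@@H](C)O`: 136000 nM
Compound 3, `C/C=C/C=C/C(=O)N[C@H](C(=O)NCCCCCCCCCCCCCCCCCC)[C@@H](C)O`: 200000 nM

In a functional assay on SW-620 cells (Homo sapiens) for cytotoxicity, read by MTT assay, with a stated time of 48 h (a lower number here means a stronger inhibitor, a higher number a weaker inhibitor), compound 3 gives 200000 nM, the highest of the two numbers reported; the nearest is compound 2, which lies within the scatter at a 1.5-fold higher number from compound 2 to compound 3 (0.17 log units; within the scatter). For compound 1 the result is a limit of the assay, (the limit of > 200000 nM in this assay, at which 1 of the 3 values shown sits), not a number. Compound 4, `CCCCCCCCCCCCCCCCCCNC(=O)[C@@H](NS(=O)(=O)c1ccc(C)cc1)[C@@H](C)O`, has not been measured; it differs from compound 3 by (4-methylphenyl)sulfonyl in place of (penta-1,3-dien-1-yl)carbonyl on an amine nitrogen. For the measured compounds named here, no measured step changes this position to a sulfonyl group, so the closest guides are the steps that vary the same acyl group among the measured compounds: an at least 1.4-fold lower number from compound 1 to compound 2 (0.16 log units; that floor lies within the scatter) and a 1.5-fold higher number from compound 2 to compound 3 (0.17 log units; within the scatter), both small, the first resting on a limit. These varied groups left the numbers near the top of the range, so compound 4 is expected to stay there too, with a step of no change at the digits printed from compound 3 to compound 4 (within the scatter), no change beyond the scatter. Compound 4 is therefore estimated at 200000 nM, with a range from 80000 nM to 400000 nM, and a considerable chance that the assay reports only a limit.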

Compound 4, half-maximal inhibitory concentration: 32500 nM
Compound 4: the middle estimate sits 6.2-fold (0.79 log units) above what was measured; the whole stated range lies above it.
By their numbers in this assay, from the lowest: compound 4; then compounds 2 and 3 (each within the scatter of the next).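

In this assay, the amine nitrogen now proves able to move the number beyond the scatter, which the readable steps among the carbonyl-linked groups did not show: (4-methylphenyl)sulfonyl in place of (penta-1,3-dien-1-yl)carbonyl gives a 6.2-fold lower number from compound 3 to compound 4 (0.79 log units; beyond the scatter). Aromatic rings alone do not separate compound 4 from the others, since compound 2 also carries one on a carbonyl, and the change from that compound still gives a 4.2-fold lower number from compound 2 to compound 4 (0.62 log units; beyond the scatter). Compound 1 gives a limit of the assay rather than a number, so an at least 6.1-fold lower number from compound 1 to compound 4 (0.78 log units; beyond the scatter) is only a floor: the limit of > 200000 nM in this assay, at which 1 of the 4 values shown sits.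

The compounds shown leave open whether the sulfonyl link or the 4-methylphenyl group accounts for the step, a question that a 4-methylbenzoyl group or a methanesulfonyl group on the same nitrogen would help to separate. They also leave open whether the step depends on the long alkyl chain, or whether it would persist with a shorter chain or with a phenylsulfonyl group lacking the methyl.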